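Extending the ethyl group of compound 3

The source may hold more compounds than are shown below. What is called first, only, known or untested is meant among the compounds shown, and "the series" means these compounds.

In a functional assay on P388 cells (Mus musculus) for cytotoxicity (a higher number here means a weaker inhibitor, a lower number a stronger inhibitor), compound 3 `CCN1C(=O)[C@@H](C)NC(=O)[C@@H]2Cc3ccc(OC)c(c3)Oc3ccc(cc3)C[C@@H](C(=O)N2C)N(C)C(=O)[C@H](C)NC(=O)[C@H](Cc2ccc(OC)cc2)N(C)C(=O)[C@@H]1C` gives 43.7 nM, within the scatter of both compound 1 `COc1ccc(C[C@H]2C(=O)N[C@@H](C)C(=O)N(C)[C@H]3Cc4ccc(cc4)Oc4cc(ccc4OC)C[C@@H](C(=O)N[C@H](C)C(=O)N[C@@H](CCO)C(=O)N2C)N(C)C3=O)cc1` at 60.3 nM and compound 2 `C=C[C@@H]1NC(=O)[C@@H](C)NC(=O)[C@@H]2Cc3ccc(OC)c(c3)Oc3ccc(cc3)C[C@@H](C(=O)N2C)N(C)C(=O)[C@H](C)NC(=O)[C@H](Cc2ccc(OC)cc2)N(C)C1=O` at 25.7 nM. Compound 4 `COc1ccc(C[C@H]2C(=O)N[C@@H](C)C(=O)N(C)[C@H]3Cc4ccc(cc4)Oc4cc(ccc4OC)C[C@@H](C(=O)N[C@H](C)C(=O)N(CC=C(C)C)[C@@H](C)C(=O)N2C)N(C)C3=O)cc1` carries 2-methylprop-1-en-1-yl in place of methyl on a saturated chain carbon bound to an amide-type nitrogen in a ring. Cut one bond further out, this reads ethyl to 3-methylbut-2-en-1-yl. Among the compounds with values here, the only measured step, a 2.3-fold lower number from compound 1 to compound 2 (0.37 log units; beyond the scatter), is modest and lies at another place, with vinyl in place of 2-hydroxyethyl on a saturated ring carbon, so it is a loose guide. The expected change is a 1.4-fold higher number from compound 3 to compound 4 (0.14 log units; within the scatter), which is not expected to exceed the scatter. Compound 4 is estimated at 60 nM, with an expected range of 22 nM to 170 nM.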

Compound 4, half-maximal inhibitory concentration: 6.92 nM
The estimate for compound 4 lay 8.7-fold (0.94 log units) above the measured number, and the stated range ends above it.
By their numbers in this assay, from the lowest: compound 4; then compounds 2, 3 and 1 (each within the scatter of the next, the first and the last beyond it).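

In this assay, the change from ethyl to 3-methylbut-2-en-1-yl gives a 6.3-fold lower number from compound 3 to compound 4 (0.80 log units; beyond the scatter). This shows that this place, a saturated chain carbon bound to an amide-type nitrogen in a ring, responds to the larger group with a number beyond the scatter, which the earlier step, made at another place, could not show. Nothing shown explains the drop. The compounds shown leave open whether the double bond or the added carbons matter, which a saturated 3-methylbutyl group could separate. Going by these compounds, whether a chain ending in an amine is accepted here also remains open.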